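Trimming the aryloxy arm of a myeloperoxidase inhibitor

The source may hold more compounds than are shown below. What is called first, only, known or untested is meant among the compounds shown, and "the series" means these compounds.

Measured compounds:
compound 1, `Nc1cc(Cc2ccn(Cc3cccc(Oc4cccc5c4CNC5)c3)n2)c2nn[nH]c2n1`: 26 nM
compound 2, `Nc1cc(C2CCNCCc3cccc(c3)Oc3cccc(c3)Cn3cc2cn3)c2nn[nH]c2n1`: 14 nM

In an assay on isolated protein for inhibition of Myeloperoxidase (Homo sapiens), with a stated time of 10 min (a higher number here means a weaker inhibitor, a lower number a stronger inhibitor), compound 1 gives 26 nM, the higher of the two numbers; compound 2 gives 14 nM, a gap that lies within the usual scatter, so the two cannot be ranked. Compound 3, `Nc1cc(Cc2ccn(Cc3cccc(O[C@H]4CCNC4)c3)n2)c2nn[nH]c2n1`, differs from compound 1 in one place: a group of 5 heavy atoms (4 carbon, 1 nitrogen; one five-membered non-aromatic ring with 1 hetero atom) in place of a group of 9 heavy atoms (8 carbon, 1 nitrogen; one five-membered non-aromatic ring with 1 hetero atom, one six-membered aromatic ring of carbon only), on an oxygen on an aromatic ring. Among the compounds with values here, no measured pair shows such a change, so the step can only be guessed. With much of the aryloxy arm removed, a loss of potency beyond the scatter is expected, and the step from compound 1 to compound 3 is estimated at a 2.7-fold higher number from compound 1 to compound 3 (0.43 log units; beyond the scatter). Compound 3 is therefore expected to give about 70 nM, within roughly 20 nM to 250 nM.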

Compound 3, half-maximal inhibitory concentration: 46 nM
For compound 3 the middle estimate is 1.5-fold (0.18 log units) above the measured one; low and high end bracket the measured number.
By their numbers in this assay, from the lowest: compounds 2, 1 and 3 (each within the scatter of the next, the first and the last beyond it).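

In this assay, the step of a 1.8-fold higher number from compound 1 to compound 3 (0.25 log units; within the scatter) comes with replacing a group of 9 heavy atoms, which includes a six-membered aromatic ring of carbon only, by pyrrolidin-3-yl, on an oxygen on an aromatic ring. On this oxygen, then, the aromatic ring of compound 1 can go without a difference that can be told from the scatter of repeated measurements. Nothing available here speaks to the reason for this result. Still open, on these data alone, is how the opposite stereoisomer of the pyrrolidin-3-yl group would compare. Also open, as far as these compounds go, is whether an open-chain amine such as 2-aminoethyl, or a plain methyl, would serve on this oxygen.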